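From ethynyl to thiophen-2-yl, with little to go on

The compounds below may be only part of what the source reports. "The series", "measured", "known", "first", "only" and "open" are said of these compounds alone.

In a functional assay on U-373MG ATCC cells for inhibition, with U373 MG (Homo sapiens) as the target, read by MTT assay, with a stated time of 7 days (on this read-out higher numbers stand for weaker inhibition of growth and lower numbers for stronger inhibition of growth), compound 1 (`NC(=O)c1ncn2c(=O)n(Cc3ccccc3)nnc12`) gives > 50000 nM, which is a limit and not a number. Compound 2 (`Cc1cc(Cn2nnc3c(C(N)=O)ncn3c2=O)on1`) gives > 50000 nM, which is also a limit. For the measured compounds named here, compound 3 (`C#CC/N=N/Nc1[nH]cnc1C(N)=O`) gives 32000 nM, the only true number in this small set. The sole other reference point is the limit of > 50000 nM in this assay, at which 2 of the 3 values shown sit.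

Compound 4 (`NC(=O)c1nc[nH]c1N/N=N/Cc1cccs1`) differs from compound 3 in one place: thiophen-2-yl in place of ethynyl on a saturated chain carbon bound to a double-bonded nitrogen. Going by the values given here, the one measured step that also swaps a group on a saturated chain carbon is a step that the two limits leave unreadable from compound 1 to compound 2, so it offers no size to carry over. The expectation therefore rests on compound 3, with its 32000 nM, and no shift beyond the usual scatter is expected in either direction. The estimated step is a 1.1-fold lower number from compound 3 to compound 4 (0.03 log units; within the scatter). For compound 4 the expected value is 30000 nM, with an estimated range from 12000 nM to 60000 nM.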

Compound 4, concentration for 50% growth inhibition: > 50000 nM
Compound 4 ended at the assay's limit; the forecaster's own chance of this, stated with the estimate: 35%; at least 1.6-fold (0.22 log units) between middle value and limit.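

At this saturated chain carbon bound to a double-bonded nitrogen, thiophen-2-yl in place of ethynyl gives an at least 1.5-fold higher number from compound 3 to compound 4 (0.19 log units; that floor lies within the scatter) in this assay. Going by these compounds, this swap therefore has a direction and a floor, unlike the earlier swap between compound 1 and compound 2, which cannot be read, but its true size stays unknown, since that floor lies within the scatter and compound 4 gives > 50000 nM, which is a limit and not a number. The thiophen-2-yl group brings no lower number here, and compound 3 stays the only compound with a true value: the limit of > 50000 nM in this assay, at which 3 of the 4 values shown sit.

On these data alone, how far compound 4 really lies from compound 3 remains open. So does whether another group at this place, such as an amine or a longer saturated chain, would give a lower number than ethynyl does.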